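The source may report more compounds than this note shows. Statements on the series, on what has been measured and on what is new or still open speak of the compounds shown alone.

Compound 1 `Nc1scc(CN2CCN(c3cccc(Cl)c3Cl)CC2)c1C(=O)c1ccc(Cl)cc1`: 1%
Compound 2 `Nc1scc(CN2CCN(c3ccc(F)cc3Cl)CC2)c1C(=O)c1ccc(Cl)cc1`: 6.1%
Compound 3 `Nc1scc(CN2CCN(C3CCCCCC3)CC2)c1C(=O)c1ccc(Cl)cc1`: 2.9%

These three compounds share one core and were measured in a functional assay on CHO cells with adenosine receptor A1 (Homo sapiens) as the target, read by cAMP accumulation and immunoassay, with a stated time of 6 min, tested at 0.01 uM; on this read-out lower numbers stand for a stronger effect and higher numbers for a weaker effect at the one concentration tested. Compound 2 sits at the upper end of the three values, yet neither of its gaps reaches beyond the scatter: the step of a number 5.1 percentage points higher from compound 1 to compound 2 (within the scatter) and the step of a number 3.2 percentage points lower from compound 2 to compound 3 (within the scatter) are both within it, so the three compounds cannot be told apart on this read-out.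

Compound 4 `Nc1scc(CN2CCN(c3cccc(F)c3)CC2)c1C(=O)c1ccc(Cl)cc1` has not yet been measured. It differs from compound 2 in one place: 3-fluorophenyl in place of 2-chloro-4-fluorophenyl on an amine nitrogen in a ring. The measured steps that bear on this change are those that swap the group on the same ring nitrogen, namely the two steps already named and also a number 1.9 percentage points higher from compound 1 to compound 3 (within the scatter), and each of them is within the scatter. On that basis no step beyond the scatter is expected in this assay for this change, and the expected step is a number 2.1 percentage points lower from compound 2 to compound 4 (within the scatter). Compound 4 is therefore estimated to give 4%, with a range from 0% to 12%.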

Compound 4, a percentage reported as activity, at one concentration (the size of the read-out at that concentration, not a potency): -18%
Estimate against measurement, compound 4: 22 percentage points above, and the stated range ends above it.
By their numbers in this assay, from the lowest: compound 4; then compounds 1, 3 and 2 (each within the scatter of the next).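

In this assay, among these compounds, the group on the ring nitrogen proves able to move the read-out beyond the scatter, which the swaps among the earlier compounds did not show: 3-fluorophenyl gives a number 24.1 percentage points lower from compound 2 to compound 4 (beyond the scatter), a number 20.9 percentage points lower from compound 3 to compound 4 (beyond the scatter) and a number 19 percentage points lower from compound 1 to compound 4 (beyond the scatter). Of the three compounds with a phenyl on this nitrogen, only compound 4 has no chlorine on that ring, but compound 3, whose cycloheptyl also has no chlorine, goes against any simple link between lacking chlorine and a lower number. Nothing measured here speaks to the cause of these steps.

The compounds shown leave open whether a plain phenyl or a methoxy-bearing phenyl on the same nitrogen would also give a lower number. They also leave open whether the step would persist with a plain benzoyl on the shared core.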